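A Methyl Added Beside Two Cytotoxicity Limits

The source may report more compounds than this note shows. Statements on the series, on what has been measured and on what is new or still open speak of the compounds shown alone.

Compound 1 `Cc1cc(-c2ccc3[nH]c(=O)nc(-c4ccccc4)c3c2)ccn1` in an ADME assay on THP-1 cells (Homo sapiens) for cytotoxicity, read by MTT assay, with a stated time of 72 h (on this read-out lower numbers stand for an effect already at smaller amounts and higher numbers for an effect only at larger amounts of compound), gives a limit of > 50000 nM.
Compound 2 `O=c1nc(-c2ccccc2)c2cc(-c3cccnc3)ccc2[nH]1` in this assay gives a limit of > 50000 nM.

Among the measured compounds shown here, compound 2 thus stands at a limit, not a number, in this assay; the only other value shown is a limit too (the limit of > 50000 nM in this assay, at which 2 of the 2 values shown sit). The step that the two limits leave unreadable from compound 1 to compound 2 is therefore unreadable. Compound 3 `Cc1ccc(-c2ccc3[nH]c(=O)nc(-c4ccccc4)c3c2)cn1` differs from compound 2 by methyl in place of hydrogen on an aromatic carbon. For the measured compounds named here, no measured step can guide this change. The step that the limit leaves unreadable from compound 2 to compound 3 is expected to remain unreadable, so another limit is expected for compound 3. Compound 3 is estimated at 60000 nM in this assay, with a range of 30000 nM to 150000 nM.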

Compound 3, half-maximal effective concentration: > 50000 nM
Compound 3 gave a limit, no number; the forecaster's own chance of this, stated with the estimate: 85%; the middle value does not contradict the limit.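

Among the compounds shown here, compound 1, compound 2 and compound 3 all sit at a limit, so no step among them can be read in this assay: the limit of > 50000 nM in this assay, at which 3 of the 3 values shown sit. The compounds shown leave open whether methyl in place of hydrogen changes the read-out at all.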